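Indole in place of isopropylphenyl on a T-type channel amide

The source may hold more compounds than are shown below. What is called first, only, known or untested is meant among the compounds shown, and "the series" means these compounds.

The two measured compounds share an amide built on a pyrazole carboxylic acid bearing a benzyl group, but differ in what sits on the amide side. Compound 1 `COc1ccc(C2(C(=O)Nc3ccn(Cc4ccccc4)n3)CC2)cc1` carries a cyclopropane spacer and a methoxyphenyl group; in an assay on HEK293 cells for inhibition of Voltage-dependent T-type calcium channel subunit alpha-1I (Homo sapiens), read by FLIPR and calcium flux, with a stated time of 3 min (a higher number here means a weaker inhibitor, a lower number a stronger inhibitor), compound 1 gives 1700 nM. Compound 2 `CC(C)c1ccc(CNC(=O)c2ccn(Cc3ccc(F)c(F)c3)n2)cc1` instead carries a 4-isopropylphenyl group on the saturated chain carbon bound to the amide nitrogen and a difluorobenzyl group on the pyrazole; in this assay compound 2 gives 40 nM, the lowest number of the two and well separated from compound 1.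

Compound 3 `O=C(NCc1ccc2[nH]ccc2c1)c1ccn(Cc2ccc(F)c(F)c2)n1` is not yet measured. It keeps everything of compound 2 except one group: 1H-indol-5-yl in place of 4-isopropylphenyl on a saturated chain carbon bound to an amide-type nitrogen. Within the data shown here, no step between two measured compounds isolates such a change, so the expectation rests on the position of compound 2 alone. A moderate loss of potency is expected, with an estimated step of a 3.8-fold higher number from compound 2 to compound 3 (0.57 log units; beyond the scatter). Compound 3 is therefore estimated at 150 nM in this assay, with a range from 40 nM to 600 nM.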

Compound 3, half-maximal inhibitory concentration: 22 nM
For compound 3 the middle estimate is 6.8-fold (0.83 log units) above the measured one; measured number below the stated range.
By their numbers in this assay, from the lowest: compounds 3 and 2 (each within the scatter of the next); then compound 1.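

Replacing 4-isopropylphenyl with 1H-indol-5-yl on a saturated chain carbon bound to an amide-type nitrogen gives a 1.8-fold lower number from compound 2 to compound 3 (0.26 log units; within the scatter) in this assay and so marks no change that this assay can resolve. Compound 1 and compound 2 differ in more than one place and could not isolate this group, whereas this pair shows that the position accepts a five-membered aromatic ring with a hetero atom and a hydrogen-bond donor, neither of which is present in 4-isopropylphenyl, while the number stays level with that of compound 2. Nothing measured here accounts for the two groups reading alike.

The compounds shown leave open whether the hydrogen on the indole nitrogen matters, which a methyl group on that nitrogen would test while the rest of compound 3 stayed the same. They also leave open how far this position extends to other groups, such as a primary amine or a carboxylic acid in place of 1H-indol-5-yl on the same saturated chain carbon.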